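This account rests on a few compounds, and the source may have more. Where it says the series, first, only, none or still open, it means among the compounds named here.

Measured compounds:
compound 1 `CCOC(=O)CCCCCOc1cccc(CN(C(=O)c2ccc(-c3cccc(NC(C)=O)c3)cc2)C(C)C)c1` – > 26000 nM
compound 2 `CCOC(=O)CCCCCOc1cccc(CN(C(=O)c2ccc(-c3cccc(OCC(C)C)c3)cc2)C(C)C)c1` – > 26000 nM

In an ADME assay on HEK293 cells (Homo sapiens) for cytotoxicity, read by CellTiter-Glo and resazurin assay, with a stated time of 72 h (on this read-out lower numbers stand for an effect already at smaller amounts and higher numbers for an effect only at larger amounts of compound), compound 1 gives > 26000 nM, which is a limit of the assay and not a number. Compound 2 gives > 26000 nM in this assay, again a limit. The step that the two limits leave unreadable from compound 1 to compound 2 is therefore not readable, since both ends sit at the limit (the limit of > 26000 nM in this assay, at which 2 of the 2 values shown sit). Compound 2 thus stands where every shown value stands, at the limit, with nothing between the two compounds to order them.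

Compound 3 `CCOC(=O)CCCCCOc1cccc(CN(C(=O)c2ccc(-c3cccc(Oc4ccccc4)c3)cc2)C(C)C)c1` differs from compound 2 by phenyl in place of isobutyl on an oxygen on an aromatic ring. For the measured compounds named here, the only measured step, a step that the two limits leave unreadable from compound 1 to compound 2, bears on this change merely in showing that a change at this same oxygen-bearing position left the read-out at the limit (the limit of > 26000 nM in this assay, at which 2 of the 2 values shown sit). Going by the values given here, no step of readable size is available, so in this assay no step beyond the scatter is expected. Compound 3 is estimated at 30000 nM, within 12000 nM to 80000 nM, which means an expected step that the limit leaves unreadable from compound 2 to compound 3.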

Compound 3, half-maximal effective concentration: > 19600 nM
Compound 3: no number, only a limit; the forecaster's own chance of this, stated with the estimate: 75%; the middle value does not contradict the limit.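

In this assay compound 3 gives > 19600 nM, which is a limit and not a number. For the compounds shown here, no step among compound 1, compound 2 and compound 3 can therefore be read. The compounds shown leave open whether acetamido, isobutoxy or phenoxy makes any difference to the read-out.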